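Replacing the ethoxycarbonyl group of compound 3

The source may report more compounds than this note shows. Statements on the series, on what has been measured and on what is new or still open speak of the compounds shown alone.

In a functional assay on DU-145 cells (Homo sapiens) for antiproliferative activity, read by MTT assay, with a stated time of 72 h (a higher number here means a weaker inhibitor, a lower number a stronger inhibitor), compound 1 `COc1cc2c(Nc3ccc(C#N)cc3)ncnc2cc1OCCCN(C)Cc1ccccc1` reaches only a limit (> 100000 nM). Compound 2 `COc1cc2c(Nc3ccc(C#N)cc3)ncnc2cc1OCCCN1CCCC1` gives 14400 nM and compound 3 `CCOC(=O)C1CCN(CCCOc2cc3ncnc(Nc4ccc(C#N)cc4)c3cc2OC)CC1` gives 52300 nM as the higher of these two numbers. Compound 4 `COc1cc2c(Nc3ccc(C#N)cc3)ncnc2cc1OCCCN1CCC(N2CCCCC2)CC1` carries piperidin-1-yl in place of ethoxycarbonyl on a saturated ring carbon. Among the compounds with values here, no measured step alters that position. The steps of an at least 6.9-fold lower number from compound 1 to compound 2 (0.84 log units; beyond the scatter) and an at least 1.9-fold lower number from compound 1 to compound 3 (0.28 log units; that floor lies within the scatter) give floors only. The nearest guide is a 3.6-fold higher number from compound 2 to compound 3 (0.56 log units; beyond the scatter) in which the side chain gains the ethoxycarbonyl-bearing ring, so losing the ethoxycarbonyl group is tentatively expected to lower the number modestly. The expected change is a 2.6-fold lower number from compound 3 to compound 4 (0.42 log units; beyond the scatter) in this assay as a modest step. Compound 4 is estimated at 20000 nM with an expected range from 6000 nM to 70000 nM in this assay as well.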

Compound 4, half-maximal inhibitory concentration: 15600 nM
Beside the measured number, compound 4's estimate is 1.3-fold (0.11 log units) above it, and the stated range covers the measured number.
By their numbers in this assay, from the lowest: compounds 2 and 4 (each within the scatter of the next); then compound 3. At a limit, above all of these: compound 1.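

In this assay, within the data shown here, the change at this saturated ring carbon, three ring bonds from the ring nitrogen, has a measurable effect: piperidin-1-yl in place of ethoxycarbonyl gives a 3.4-fold lower number from compound 3 to compound 4 (0.53 log units; beyond the scatter) as the only step measured at this position. Against the pyrrolidin-1-yl side chain, 4-(piperidin-1-yl)piperidin-1-yl gives a 1.1-fold higher number from compound 2 to compound 4 (0.03 log units; within the scatter) and so leaves the two compounds level. The step of an at least 6.4-fold lower number from compound 1 to compound 4 (0.80 log units; beyond the scatter) is only a floor, as compound 1 stands at a limit: the limit of > 100000 nM in this assay, at which 1 of the 4 values shown sits.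

As far as these compounds go, whether a carboxylic acid or a primary amine on this ring carbon would match piperidin-1-yl remains open. So does the effect of a longer chain between the oxygen and the ring nitrogen.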